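The source may report more compounds than this note shows. Statements on the series, on what has been measured and on what is new or still open speak of the compounds shown alone.

Compound 1 `Cc1cc(C)c(S(=O)(=O)N[C@@H](CNC(=O)C2=NO[C@]3(C2)C[C@@H](CNc2ccccn2)N(C(=O)OCc2ccccc2)C3)C(=O)O)c(C)c1`: 0.18 nM
Compound 2 `O=C(NC[C@@H](C(=O)O)S(=O)(=O)c1ccccc1)C1=NOC2(CCC(CNc3ncc[nH]3)CC2)C1`: 4700 nM
Compound 3 `Cc1cc(C)c(S(=O)(=O)[C@@H](CNC(=O)C2=NOC3(CCC(C(=O)Nc4ncc[nH]4)CC3)C2)C(=O)O)c(C)c1`: 2700 nM

These three compounds were tested in a functional assay for antagonist activity at integrin alpha-5/beta-1 (Homo sapiens), read by ELISA; on this read-out higher numbers stand for weaker inhibition and lower numbers for stronger inhibition. Compound 1 has the lowest number of the three, and its gaps to compound 3 and to compound 2 both lie well beyond the scatter of this assay; compounds 2 and 3 differ from compound 1 in several places at once, so their values only show that those other arrangements inhibit far more weakly. Compound 4 `Cc1cc(C)c(S(=O)(=O)N[C@@H](CNC(=O)C2=NO[C@]3(C2)C[C@@H](CNc2ncc[nH]2)N(C(=O)OCc2ccccc2)C3)C(=O)O)c(C)c1` has not yet been measured. It differs from compound 1 in one place: 1H-imidazol-2-yl in place of pyridin-2-yl on an amine nitrogen. Among the measured compounds shown here, no pair of measured compounds shows this single change on its own, so nothing here tells how large a step it should bring. Compound 4 is expected to stay close to compound 1, with a step from compound 1 to compound 4 of a 2.8-fold higher number from compound 1 to compound 4 (0.44 log units; beyond the scatter), a small loss that could also be none beyond the scatter. For compound 4 the estimate in this assay is 0.5 nM, within a range of 0.1 nM to 5 nM.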

Compound 4, half-maximal inhibitory concentration: 18 nM
The estimate for compound 4 lay 36-fold (1.56 log units) below the measured number; measured number outside the range, above it.
By their numbers in this assay, from the lowest: compound 1; then compound 4; then compounds 3 and 2 (each within the scatter of the next).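

In this assay, replacing pyridin-2-yl with 1H-imidazol-2-yl on the amine nitrogen, with the rest of the molecule unchanged, brings a 100-fold higher number from compound 1 to compound 4 (2.00 log units; beyond the scatter), so inhibition depends strongly on which ring sits at this position. The earlier compounds shown here could not show this, since they differ from compound 1 in several places at once. The change swaps a six-membered aromatic ring without a hydrogen-bond donor for a five-membered one with a hydrogen-bond donor, but this single pair cannot separate those two differences, and no measurement here accounts for the large step.

Going by these compounds, it remains open whether a pyrimidin-2-yl ring or a phenyl ring on the same nitrogen would give a number closer to that of compound 1 or compound 4. On these data alone, it is also open whether this swap would bring a step of similar size on a different core.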